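Adding an Acetoxy Group to a Weakly Active Sulfonamide

The compounds below may be only part of what the source reports. "The series", "measured", "known", "first", "only" and "open" are said of these compounds alone.

Compound 1, `COc1ccc(C(=O)NOCc2ccccc2)cc1S(=O)(=O)Nc1ccc2c(c1)cc(C)c(=O)n2C`: 2%
Compound 2, `COC(=O)c1ccc(S(=O)(=O)Nc2ccc3c(c2)cc(C)c(=O)n3C)c(OC)c1`: 5%

In a functional assay on HL-60 cells (Homo sapiens) for antiproliferative activity, tested at 1 uM (on this read-out higher numbers stand for a stronger effect at the one concentration tested and lower numbers for a weaker effect), compound 1 gives 2%. Compound 2 gives 5% in this assay, and the gap between the two numbers lies within the scatter, so the two compounds cannot be told apart; both sit near the bottom of the scale.

Compound 3, `COc1ccc(C(=O)NOCc2ccc(OC(C)=O)cc2)cc1S(=O)(=O)Nc1ccc2c(c1)cc(C)c(=O)n2C`, has not been measured. It is built from compound 1 by the change (acetoxy in place of hydrogen on an aromatic carbon). Going by the values given here, no pair of measured compounds differs in this way, so there is no measured step to lean on. Given that the only two measured compounds are low and indistinguishable, the step expected from compound 1 to compound 3 in this assay is a number 3 percentage points higher from compound 1 to compound 3 (within the scatter), which is none beyond the scatter. Compound 3 is therefore estimated to give 5%, within a range from 0% to 15%.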

Compound 3, a percentage reported as inhibition, at one concentration (the size of the read-out at that concentration, not a potency): 0%
The estimate for compound 3 lay 5 percentage points above the measured number; the range from low to high includes it.
By their numbers in this assay, from the lowest: compounds 3, 1 and 2 (each within the scatter of the next).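

In this assay, going by these compounds alone, the change from benzyl to 4-acetoxybenzyl gives a number 2 percentage points lower from compound 1 to compound 3 (within the scatter), the first reading of any change on this aromatic ring. Adding acetoxy here, with its 4 heavy atoms, therefore produces no effect that can be told from the scatter, and compound 3 stays near the bottom of the scale with compound 1. Nothing available explains this outcome.

With compound 1 already so low, this read-out could show a gain far more clearly than a loss, so a harmful effect of acetoxy cannot be ruled out. The compounds shown leave open whether a different group at this place, such as a hydroxyl, an amine or a carboxylic acid, would raise the effect beyond the scatter.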